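The source may report more compounds than this note shows. Statements on the series, on what has been measured and on what is new or still open speak of the compounds shown alone.

In a functional assay on MDA-MB-468 cells (Homo sapiens) for antiproliferative activity (a higher number here means a weaker inhibitor, a lower number a stronger inhibitor), compound 1 (`Cc1cc(-c2nc3ccccc3s2)ccc1N`) gives < 1 nM, which is a limit of the assay and not a number. Compound 2 (`Nc1ccc(-c2nc3ccccc3s2)cc1Cl`) gives < 1 nM, which is also a limit. Compound 3 (`CC(=O)Nc1ccc(-c2nc3ccccc3s2)cc1C`) gives > 10000 nM, again a limit, and this places it at the weak end of the values shown.

Compound 4 (`CC(=O)Nc1ccc(-c2nc3ccccc3s2)cc1Cl`) differs from compound 3 by one exchange, chloro in place of methyl on an aromatic carbon, ortho to an acetamido group. Among the compounds with values here, two measured steps bear on it. The same exchange, made without the acetyl group, appears as a step that the two limits leave unreadable from compound 1 to compound 2, so it offers no size to carry over. The acetyl in place of hydrogen on a nitrogen on an aromatic ring appears as an at least 10000-fold higher number from compound 1 to compound 3 (4.00 log units; beyond the scatter), and this large loss is the firmer guide, since compound 4 also carries the acetyl group.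

Compound 4 is therefore expected to stay weak in this assay, though the unreadable step from compound 1 to compound 2 leaves real uncertainty. The expected change is an at least 1.2-fold lower number from compound 3 to compound 4 (0.09 log units; that floor lies within the scatter), with no firm direction estimated, and another limit is quite possible. For compound 4 the estimated value is 8000 nM, within an expected range of 300 nM to 30000 nM.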

Compound 4, half-maximal inhibitory concentration: > 100 nM
Compound 4: only a limit was reported (the forecaster's own chance of this, stated with the estimate: 60%); the middle value is on the limit's open side.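

The acetyl in place of hydrogen on the nitrogen now shows a large loss with chloro on the ring, not only with methyl, in this assay: an at least 100-fold higher number from compound 2 to compound 4 (2.00 log units; beyond the scatter). The two steps of chloro in place of methyl, one between the free amines and one between the acetamido compounds, both rest on limits and cannot be read, so this exchange still has no measured size with either nitrogen group. The two acetyl steps agree in direction, while their sizes cannot be compared: the same change on two cores in this assay, an at least 10000-fold higher number (4.00 log units; beyond the scatter) from compound 1 to compound 3 and an at least 100-fold higher number (2.00 log units; beyond the scatter) from compound 2 to compound 4; the limit leaves it open whether they differ

The compounds shown leave open where the true values of compound 3 and compound 4 lie, and so whether chloro and methyl differ at all when the nitrogen carries the acetyl group. They also leave open how a formyl group, a longer acyl chain or a single methyl on that nitrogen would read, and whether fluoro or methoxy in place of chloro would give a readable step alongside the free amine.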